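A few compounds are considered here, and "the series" means these few. Any claim that something is new, unique, unknown or untested is made for them only; others in the source may bear on it.

Measured compounds:
compound 1, `O=C(c1ccccc1)N1CCC(N(C2CC2)S(=O)(=O)c2cccc(C(F)(F)F)c2)CC1`, "not determined" (no result reported)
compound 2, `O=C(c1ccccc1OC(F)(F)F)N1CCC(N(C2CC2)S(=O)(=O)c2cccc(C(F)(F)F)c2)CC1`, "not determined" (no result reported)
compound 3, `NC(=O)c1ccc(C(=O)N2CCC(N(C3CC3)S(=O)(=O)c3cccc(C(F)(F)F)c3)CC2)cc1`, 0%

Compound 1 has no number of its own in an assay on cells for inhibition of Voltage-dependent L-type calcium channel subunit alpha-1C (Homo sapiens), read by FLIPR and calcium flux, tested at 3 uM; a higher number here means a stronger effect of the compound at the concentration tested, a lower number a weaker effect; its entry, like that of compound 2, reports no result. Within the data shown here, the only measured value in the set belongs to compound 3, which gives 0% in this assay. Among the measured compounds shown here, compound 1 therefore stands without a value, and no step between measured compounds can be drawn from these three entries.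

Compound 4, `CS(=O)(=O)c1ccccc1C(=O)N1CCC(N(C2CC2)S(=O)(=O)c2cccc(C(F)(F)F)c2)CC1`, is the compound yet to be measured. It differs from compound 1 by methylsulfonyl in place of hydrogen on an aromatic carbon, placed on an aromatic carbon of a six-membered aromatic ring of carbon only. For the measured compounds named here, with no number for compound 1 and only the result of compound 3 to go by, there is no measured step to anchor the direction of this change; the one measured value in the set is at the bottom of the scale, so any change beyond the scatter would have to be upward, and nothing here indicates such an effect. For compound 4 in this assay a value of 5% is expected, within a range from -10% to 25%.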

Compound 4, a percentage reported as inhibition, at one concentration (the size of the read-out at that concentration, not a potency): 39%
The estimate for compound 4 lay 34 percentage points below the measured number, outside the stated range (above it).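

In this assay, the series now has its first readable step: 2-(methylsulfonyl)phenyl in place of 4-carbamoylphenyl on the carbonyl carbon gives a number 39 percentage points higher from compound 3 to compound 4 (beyond the scatter), so the aryl group on this carbonyl carbon can shift the read-out. Among these compounds, until now the only number in the set was that of compound 3 at 0%, whereas compound 4 reaches 39% with methylsulfonyl on an aromatic carbon, ortho to a large group. Nothing measured here explains this rise.

Steps from compound 1 or compound 2 cannot be read, so the part played by methylsulfonyl itself, compared with hydrogen, stays unknown, as does the separate part played by losing the carbamoyl group of compound 3. On these data alone, it also remains open how an amine, a carboxylic acid or a longer alkylsulfonyl chain would read at this same place.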